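From a naphthyl ester to the free carboxylic acid

The compounds below may be only part of what the source reports. "The series", "measured", "known", "first", "only" and "open" are said of these compounds alone.

Compound 1 `O=C(NCc1ccccc1)c1cn(-c2ccccc2)nc1-c1ccncc1`: in a functional assay on Raji cells (Homo sapiens) for cytotoxicity, read by MTT assay, with a stated time of 48 h (on this read-out higher numbers stand for weaker inhibition and lower numbers for stronger inhibition), compound 1 gives > 100000 nM, which is a limit of the assay rather than a number.
Compound 2 `CCc1ccc(OC(=O)c2cn(-c3ccccc3)nc2-c2ccncc2)cc1`: in this assay compound 2 gives "nd(insoluble)" (no result reported), so no result was obtained; the entry records the compound as insoluble.
Compound 3 `O=C(Oc1ccc2ccccc2c1)c1cn(-c2ccccc2)nc1-c1ccncc1`: in this assay compound 3 gives 12100 nM.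

All three share the same core, a pyrazole bearing a phenyl group and a pyridyl group, and differ only in what hangs from the carbonyl. For the measured compounds named here, compound 3 stands alone as the only compound with a measured number; one further value is a limit and one entry carries no number at all. The benzylamide, compound 1, sits at the limit described by the limit of > 100000 nM in this assay, at which 1 of the 3 values shown sits.

The next step removes the aromatic ester entirely: hydrogen in place of naphthalen-2-yl on an oxygen next to a carbonyl group, giving compound 4 `O=C(O)c1cn(-c2ccccc2)nc1-c1ccncc1`, the free carboxylic acid. Going by the values given here, no measured pair of compounds differs in just one place, so there is no step of known size to lean on. The expectation, resting on compound 3 and its value of 12100 nM, is a move toward weaker inhibition that goes beyond the usual scatter. Compound 1 already sits at a limit of the assay, and compound 4 may likewise end up where only a limit is reported. Compound 4 is therefore expected to give 80000 nM, within a range from 20000 nM to 300000 nM. The expected step of a 6.6-fold higher number from compound 3 to compound 4 (0.82 log units; beyond the scatter) is sizeable and in the direction of weaker cytotoxicity.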

Compound 4, half-maximal inhibitory concentration: > 100000 nM
Compound 4: only a limit was reported; the forecaster's own chance of this, stated with the estimate: 60%; middle value at least 1.2-fold (0.09 log units) from the limit.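

For the compounds shown here, replacing naphthalen-2-yl with hydrogen on the oxygen next to a carbonyl group gives, in this assay, an at least 8.2-fold higher number from compound 3 to compound 4 (0.91 log units; beyond the scatter), the first readable step in this set, and it lies beyond the scatter. Within this pair, a measurable cytotoxic effect depends on what sits on that oxygen: with naphthalen-2-yl there is a number, and with hydrogen there is none, so the shared core with a free carboxylic acid is not enough to give a reportable value. Compound 4 gives only a limit, the same one already reached elsewhere in this small series: the limit of > 100000 nM in this assay, at which 2 of the 4 values shown sit.

Going by these compounds, the true size of the step from naphthalen-2-yl to hydrogen stays unknown, and the step between compound 1 and compound 4 cannot be read, as both values are limits. On these data alone, it also remains open whether a small group such as methyl on that oxygen would keep any of the effect of compound 3, or whether a single unsubstituted phenyl ring would do as well as naphthalen-2-yl.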